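The source may hold more compounds than are shown below. What is called first, only, known or untested is meant among the compounds shown, and "the series" means these compounds.

Of the compounds shown here, three of the same shared core have been measured. Compound 1 `COC(=O)/C=C/c1cccc(N(Cc2ccc(/C=C/c3cccc(C(F)(F)F)c3)cc2)C(=O)NC(C)C)c1`, compound 2 `COC(=O)/C=C/c1cccc(N(Cc2ccc(/C=C/c3c(F)cccc3F)cc2)C(=O)C(C)C)c1` and compound 3 `COC(=O)/C=C/c1cccc(N(Cc2ccc(-c3ccc(F)c(F)c3)cc2)C(=O)C2CCCCC2)c1` were tested in an assay on isolated protein with Bile acid receptor (Homo sapiens) as the target; a lower number here means that less compound is needed, a higher number that more compound is needed for the effect. Compound 1 gives 932 nM, compound 2 gives 108 nM and compound 3 gives 72 nM. Compound 2 thus stands second highest of the three: its number lies close to that of compound 3, within the scatter, and well below that of compound 4's nearest comparator compound 1, a gap beyond the scatter. Compound 4 `COC(=O)/C=C/c1cccc(N(Cc2ccc(-c3ccc(F)c(Cl)c3)cc2)C(=O)C(C)C)c1` differs from compound 2 in one place: 3-chloro-4-fluorophenyl in place of 2-(2,6-difluorophenyl)ethenyl on an aromatic carbon. Compound 3 shows that a directly attached fluorinated phenyl ring is well tolerated on this core, so no step beyond the scatter is expected from compound 2 to compound 4 in this assay, the expected step being a 1.3-fold lower number from compound 2 to compound 4 (0.10 log units; within the scatter). Compound 4 is therefore expected to give about 85 nM, within a range of 30 nM to 250 nM.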

Compound 4, half-maximal effective concentration: 129 nM
The estimate for compound 4 lay 1.5-fold (0.18 log units) below the measured number, within the range that was stated.
By their numbers in this assay, from the lowest: compounds 3, 2 and 4 (each within the scatter of the next); then compound 1.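

In this assay, 3-chloro-4-fluorophenyl in place of 2-(2,6-difluorophenyl)ethenyl gives a 1.2-fold higher number from compound 2 to compound 4 (0.08 log units; within the scatter). This one-place comparison shows that, on this aromatic carbon para to a large group, the ethenyl-linked ring can give way to a directly attached ring, losing the double bond outside aromatic rings, without a step beyond the scatter. Nothing available gives a reason for this result. The compounds shown leave open how a different kind of group at this position, such as an amine or a carboxylic acid, would read in this assay.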